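Replacing the cyclohexyl group of compound 3

The source may report more compounds than this note shows. Statements on the series, on what has been measured and on what is new or still open speak of the compounds shown alone.

Of the compounds shown here, three built on closely related cores have been tested in a functional assay on a cell-free system (plasma, Homo sapiens), with a stated time of 3 min; a higher number here means a weaker inhibitor, a lower number a stronger inhibitor. Compound 1 (`O=C(NCc1cc(Cl)ccc1-n1cnnn1)[C@@H]1C[C@@H]2C[C@@H]2N1C(=O)[C@H](O)C1CCCCC1`) gives 600 nM, compound 2 (`O=C(NCc1cc(Cl)ccc1-n1cnnn1)[C@@H]1[C@@H]2C[C@@H]2CN1C(=O)[C@H](O)c1ccccc1F`) gives 580 nM, and compound 3 (`O=C(NCc1cc(Cl)ccc1-n1cnnn1)[C@@H]1[C@H]2C[C@H]2CN1C(=O)[C@H](O)C1CCCCC1`) gives 850 nM. These three numbers all lie within the usual scatter of one another, so compound 3 cannot be told apart from compound 1 or compound 2.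

Compound 4 (`O=C(NCc1cc(Cl)ccc1-n1cnnn1)[C@@H]1[C@H]2C[C@H]2CN1C(=O)[C@H](O)CC1CC1`) is compound 3 with a single group exchanged: cyclopropylmethyl in place of cyclohexyl on a saturated chain carbon bound to a carbonyl carbon and an oxygen on a saturated carbon. In words, this is cyclopropylmethyl in place of cyclohexyl on a saturated chain carbon bound to a carbonyl carbon and an oxygen on a saturated carbon.

Among the measured compounds shown here, no two measured compounds differ in only one place, so the data offer no direct measure of this exchange. One weak clue remains: compound 2 carries a different group at that carbon and gives 580 nM, which hints that a change there need not shift the number far. The entering group is also smaller than the one it replaces, so a small move towards a weaker inhibitor seems the likelier outcome in this assay. The expected change is a 1.8-fold higher number from compound 3 to compound 4 (0.25 log units; within the scatter).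

Compound 4 is estimated at 1500 nM, with an expected range of 500 nM to 4500 nM.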

Compound 4, half-maximal inhibitory concentration: 1400 nM
Beside the measured number, compound 4's estimate is 1.1-fold (0.03 log units) above it; the measured number falls inside the stated range.
By their numbers in this assay, from the lowest: compounds 2, 1, 3 and 4 (each within the scatter of the next, the first and the last beyond it).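

Among the compounds shown here, this is the first pair of measured compounds that differ in one place, so the exchange of cyclohexyl for cyclopropylmethyl can now be read directly: in this assay, it gives a 1.6-fold higher number from compound 3 to compound 4 (0.22 log units; within the scatter), a step that lies within the usual scatter. On a saturated chain carbon bound to a carbonyl carbon and an oxygen on a saturated carbon, going from 6 heavy atoms to 4 heavy atoms, and from a six-membered ring to a three-membered ring, therefore leaves compound 3 and compound 4 impossible to tell apart in this assay. No measurement at hand explains why these two groups read alike.

On these data alone, both groups are carbon only, with 0 hydrogen-bond donors and 0 hydrogen-bond acceptors, so it remains open how the number would respond to an amine or a carboxylic acid at this carbon, or to a much longer chain such as n-octyl. As far as these compounds go, it also remains open whether the same exchange would read alike on the cores of compound 1 and compound 2, which differ from compound 3 in more than one place.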